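The compounds below may be only part of what the source reports. "The series", "measured", "known", "first", "only" and "open" are said of these compounds alone.

Series notes. Compound 1 `CCCCCCCCNc1nc(SCc2ccc(C(F)(F)F)cc2)nc2ccccc12` carries an octyl group on the ring nitrogen and gives 22300 nM in a functional assay on MDA-MB-231 cells (Homo sapiens) for cytotoxicity, read by MTT assay, with a stated time of 72 h; on this read-out lower numbers stand for stronger inhibition and higher numbers for weaker inhibition. Compound 2 `FC(F)(F)c1ccc(CSc2nc(Nc3ccccc3Cl)c3ccccc3n2)cc1` is the analogue with 2-chlorophenyl in the same place; in this assay compound 2 returns > 50000 nM, which is a limit of the assay and not a number. The step of an at least 2.2-fold higher number from compound 1 to compound 2 (0.35 log units; beyond the scatter) is therefore at least modest and beyond the scatter; it rests on (the limit of > 50000 nM in this assay, at which 1 of the 2 values shown sits), so its true size is open. Compound 3 `FC(F)(F)c1ccc(CSc2nc(Nc3cccc(C(F)(F)F)c3)c3ccccc3n2)cc1` follows from compound 2 by 3-(trifluoromethyl)phenyl in place of 2-chlorophenyl on a nitrogen on an aromatic ring. Among the measured compounds shown here, no measured step exchanges one aryl group for another on that nitrogen; the only step available is an at least 2.2-fold higher number from compound 1 to compound 2 (0.35 log units; beyond the scatter), which shows that an aryl group in place of the octyl chain weakened inhibition. With compound 2 already at the limit, there is no ground to expect the trifluoromethylphenyl analogue to recover the level of compound 1, and its number is expected to remain near or beyond the limit. Compound 3 is therefore estimated at 60000 nM in this assay, with a range from 20000 nM to 180000 nM. The expected step is a step that the limit leaves unreadable from compound 2 to compound 3, within the scatter.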

Compound 3, half-maximal inhibitory concentration: 11100 nM
For compound 3 the middle estimate is 5.4-fold (0.73 log units) above the measured one; measured number below the stated range.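

In this assay, the aryl groups on this nitrogen are not interchangeable: an at least 4.5-fold lower number from compound 2 to compound 3 (0.65 log units; beyond the scatter), which shows that the choice of aryl group matters, something the earlier step from the octyl chain could not show. On these data alone, for compound 2 the value is a limit of the assay and not a number, so the true size of that step remains open: the limit of > 50000 nM in this assay, at which 1 of the 3 values shown sits. Replacing octyl with an aryl group therefore does not always weaken inhibition, since the step for 3-(trifluoromethyl)phenyl in place of octyl is a 2.0-fold lower number from compound 1 to compound 3 (0.30 log units; within the scatter), so among the three compounds the loss seen on this nitrogen goes with 2-chlorophenyl only.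

The two aryl groups differ both in the substituent and in where it stands on the phenyl ring, so these compounds do not separate the two changes. Also open, as far as these compounds go, is how an unsubstituted phenyl, a 3-chlorophenyl or a shorter alkyl chain on this nitrogen would compare with compound 3.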